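The compounds below may be only part of what the source reports. "The series", "measured", "known", "first", "only" and "open" are said of these compounds alone.

Measured compounds:
- compound 1 `Cc1ccc(-n2cc(CSC(=S)N3CCN(C(=O)OC(C)(C)C)CC3)nn2)cc1`: in a functional assay on MCF7 cells (Homo sapiens) for inhibition, read by MTT assay, with a stated time of 72 h (a lower number here means a stronger inhibitor, a higher number a weaker inhibitor), compound 1 gives 74200 nM
- compound 2 `S=C(SCc1cn(Cc2ccc(Cl)c(Cl)c2)nn1)N1CCNCC1`: in this assay compound 2 gives "not determined" (no result reported)

Compound 2 stands without a number: nothing in this assay was reported for it, so it offers no anchor of its own. Compound 3 `CC(C)(C)OC(=O)N1CCN(C(=S)SCc2cn(Cc3ccc(Cl)c(Cl)c3)nn2)CC1` differs from compound 2 in one place: tert-butoxycarbonyl in place of hydrogen on an amine nitrogen in a ring. Since compound 2 has no measured value, no direction or size of step in this assay can be read from the numbers between compound 2 and compound 3. Among the compounds with values here, the only measured guide is compound 1, which also carries a tert-butoxycarbonyl on the ring nitrogen and is a weak inhibitor. Compound 3 is expected to land in a similarly weak region, estimated at 50000 nM with a range from 12000 nM to 200000 nM, because compound 1 gives 74200 nM in this assay.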

Compound 3, half-maximal inhibitory concentration: 19100 nM
Compound 3: middle estimate off by 2.6-fold (0.42 log units), on the high side; measured number inside the range.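

In this assay, placing 3,4-dichlorobenzyl instead of 4-methylphenyl on the aromatic nitrogen, with the tert-butoxycarbonyl on the ring nitrogen unchanged, gives a 3.9-fold lower number from compound 1 to compound 3 (0.59 log units; beyond the scatter) as a modest gain in strength. Within the data shown here, this is the first sign that the group on this aromatic nitrogen can shift the number, something compound 1 alone could not show. Nothing measured here explains the shift.

As far as these compounds go, the step from compound 2 to compound 3 cannot be read, so the effect of tert-butoxycarbonyl in place of hydrogen on the ring nitrogen stays open. The change from compound 1 to compound 3 also alters both the chlorine and methyl substituents and the link to the aromatic nitrogen, and a plain benzyl group on that nitrogen would help to separate these changes.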